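The source may hold more compounds than are shown below. What is called first, only, known or untested is meant among the compounds shown, and "the series" means these compounds.

Within the data shown here, in a functional assay on HepG2 cells (Homo sapiens) for cytotoxicity, read by MTT assay, with a stated time of 48 h (on this read-out lower numbers stand for stronger inhibition and higher numbers for weaker inhibition), compound 1 `COc1cc(/C=C/C(=O)/C=C/c2nc3ccccc3n2C)ccc1O` gives 2900 nM and compound 2 `COc1cc(/C=C/C(=O)/C=C/c2nc3cc(C)ccc3n2C)ccc1O` gives 4200 nM, so compound 2 stands within the scatter of the only other measured number. Compound 3 `COc1ccc2c(c1)nc(/C=C/C(=O)/C=C/c1ccc(O)c(OC)c1)n2C` differs from compound 2 by methoxy in place of methyl on an aromatic carbon. Among the measured compounds shown here, the one measured step bearing on this is a 1.4-fold higher number from compound 1 to compound 2 (0.16 log units; within the scatter), which swaps hydrogen for methyl on an aromatic carbon. No change beyond the scatter is therefore expected in this assay. The estimated step is a 1.2-fold lower number from compound 2 to compound 3 (0.08 log units; within the scatter). For compound 3 the estimated value is 3500 nM, with an expected range of 1500 nM to 8000 nM.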

Compound 3, half-maximal inhibitory concentration: 3800 nM
Compound 3: middle estimate off by 1.1-fold (0.04 log units), on the low side; the range from low to high includes it.
By their numbers in this assay, from the lowest: compounds 1, 3 and 2 (each within the scatter of the next).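

In this assay, methoxy at this place gives a 1.1-fold lower number from compound 2 to compound 3 (0.04 log units; within the scatter) and a 1.3-fold higher number from compound 1 to compound 3 (0.12 log units; within the scatter), so neither methoxy nor methyl moves the number beyond the scatter set by hydrogen. The oxygen and the hydrogen-bond acceptor that enter with methoxy therefore leave no readable mark on this read-out. No independent measurement bears on this result.

On these data alone, whether an amine, a carboxylic acid or a longer chain such as ethoxy at this place would move the number beyond the scatter stays open. Also open, as far as these compounds go, is whether methoxy on another carbon of this ring would behave the same way.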